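The source may report more compounds than this note shows. Statements on the series, on what has been measured and on what is new or still open speak of the compounds shown alone.

Measured in a functional assay on HCT-8 cells (Homo sapiens) for antiproliferative activity, read by MTT assay, with a stated time of 48 h; a higher number here means a weaker inhibitor, a lower number a stronger inhibitor:
compound 1 `COc1ccc(C(=O)c2ccc(OC)c3c2OC(C)(C)C=C3)c(NC(=O)CO)c1` gives 230 nM
compound 2 `COc1ccc(C(=O)c2ccc(OC)c3c2C=CC(C)(C)O3)c(NC(=O)CO)c1` gives 630 nM
compound 3 `COc1ccc(C(=O)c2ccc(OC)c3c2OC(C)(C)C=C3)c(NC(=O)CN)c1` gives 370 nM

Compound 1 and compound 2 have the same atoms joined differently, and the difference between the two cores is not broken down here. Their values show compound 2 with the higher number of the two. One change has been measured within the series: from compound 1 to compound 3, (amino in place of hydroxy on a saturated chain carbon bound to a carbonyl carbon), giving a 1.6-fold higher number from compound 1 to compound 3 (0.21 log units; within the scatter).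

Compound 4 `COc1ccc(C(=O)c2ccc(OC)c3c2C=CC(C)(C)O3)c(NC(=O)CN)c1` is not yet measured. It stands to compound 2 as compound 3 stands to compound 1, by amino in place of hydroxy on a saturated chain carbon bound to a carbonyl carbon, the same change at the same place. Among the compounds with values here, the expectation for compound 4 rests on the single measured instance of this change, a 1.6-fold higher number from compound 1 to compound 3 (0.21 log units; within the scatter), applied to compound 2 at 630 nM. For compound 4 a step of a 1.6-fold higher number from compound 2 to compound 4 (0.20 log units; within the scatter) is expected in this assay, a little larger than the measured one to allow for the scatter. Compound 4 is estimated at 1000 nM, within a range from 450 nM to 2200 nM.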

Compound 4, half-maximal inhibitory concentration: 1050 nM
For compound 4 the middle estimate is 1.1-fold (0.02 log units) below the measured one; low and high end bracket the measured number.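

In this assay, amino in place of hydroxy on a saturated chain carbon bound to a carbonyl carbon gives a 1.7-fold higher number from compound 2 to compound 4 (0.22 log units; within the scatter) on the core of compound 2. Set beside the step on the core of compound 1, the two steps agree: the same change on two cores in this assay, a 1.6-fold higher number (0.21 log units; within the scatter) from compound 1 to compound 3 and a 1.7-fold higher number (0.22 log units; within the scatter) from compound 2 to compound 4, 1.0-fold (0.02 log units) apart, within the scatter of two such steps. The change therefore carries from one core to the other with a matching step, but each step lies within the scatter, so neither core shows a real effect of the change, and these two cores say nothing about any other core.

Still open, as far as these compounds go, is what a dimethylamino group or a carboxylic acid in place of the amino would give at this place, and what a longer chain between the carbonyl and the amine would give. Also open, from the compounds shown here alone, is whether the steps for those groups would stay as alike on the two cores in this assay.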